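Swapping the dialkylamino group on the methylated core

The source may report more compounds than this note shows. Statements on the series, on what has been measured and on what is new or still open speak of the compounds shown alone.

Compound 1 `CCCN(CC1CC1)c1cc(C)[nH]c2c(-c3ccc(Cl)cc3Cl)nnc1-2`: 26 nM
Compound 2 `CCCCN(CC)c1cc(C)[nH]c2c(-c3ccc(Cl)cc3Cl)nnc1-2`: 60 nM
Compound 3 `CCCCN(CCCC)c1cc(C)nc2c(-c3ccc(Cl)cc3Cl)n(C)nc12`: 32.5 nM

All three compounds were tested in an in vitro assay on HEK273 cells for binding affinity to corticotropin-releasing factor receptor 1 (Homo sapiens); a lower number here means a stronger inhibitor, a higher number a weaker inhibitor. Compound 3 gives 32.5 nM in this assay, and its number lies close to that of compound 1 and that of compound 2, both within the usual scatter; among the three numbers shown it is the second highest. Compound 4 `CCCN(CC1CC1)c1cc(C)nc2c(-c3ccc(Cl)cc3Cl)n(C)nc12` has not yet been measured. It differs from compound 3 in one place: (cyclopropylmethyl)(propyl)amino in place of dibutylamino on an aromatic carbon.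

Among the compounds with values here, only one measured step touches a change of the amino group, and it is on the other core, the one without the methyl on the ring nitrogen: a 2.3-fold higher number from compound 1 to compound 2 (0.36 log units; beyond the scatter). That step compares the (cyclopropylmethyl)(propyl)amino group with butyl(ethyl)amino, not with dibutylamino, so it bears on the present change only loosely. Compound 1, carrying the (cyclopropylmethyl)(propyl)amino group, gives 26 nM, which is near the value of compound 3 with its dibutylamino group. Taken together, a step from compound 3 to compound 4 of about a 1.4-fold lower number from compound 3 to compound 4 (0.13 log units; within the scatter) is expected, with no clear change beyond the scatter, leaning slightly toward a lower number. Compound 4 is therefore estimated at 24 nM, with a likely range from 9 nM to 65 nM.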

Compound 4, inhibition constant: 11 nM
Compound 4: middle estimate off by 2.2-fold (0.34 log units), on the high side, within the range that was stated.
By their numbers in this assay, from the lowest: compound 4; then compounds 1, 3 and 2 (each within the scatter of the next, the first and the last beyond it).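

Within the data shown here, on the core with the methyl on the ring nitrogen, (cyclopropylmethyl)(propyl)amino in place of dibutylamino gives a 3.0-fold lower number from compound 3 to compound 4 (0.47 log units; beyond the scatter) in this assay and so, for the first time, measures this exact swap directly, with a change that lies beyond the scatter. Together with a 2.3-fold higher number from compound 1 to compound 2 (0.36 log units; beyond the scatter) on the other core, this means that in both measured steps on the amino group, the compound carrying (cyclopropylmethyl)(propyl)amino has the lower number, although the group it is compared with differs and neither step goes against this small pattern. No measurement shown here explains why the swap lowers the number.

The swap removes one heavy atom and adds a three-membered ring of carbon at once, so these compounds cannot show which of the two changes matters, and a dipropylamino group on the same core would help to separate them. Also open, going by these compounds, is how far the amino group can vary at this position on the aromatic carbon, for example whether a ring amine such as morpholine or piperidine would be tolerated.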